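The compounds below may be only part of what the source reports. "The series", "measured", "known", "first", "only" and "open" are said of these compounds alone.

Of the compounds shown here, three from one series have been measured in a functional assay on CCRF-CEM cells (Homo sapiens) for inhibition; on this read-out higher numbers stand for weaker inhibition and lower numbers for stronger inhibition. Compound 1 `CCOC(=O)CC[C@H](NC(=O)CC[C@H](NC(=O)c1ccc(N(C)Cc2cnc3nc(N)nc(N)c3n2)cc1)C(=O)OCC)C(=O)OCC` gives 1.8 ug/mL, compound 2 `CCOC(=O)CC[C@H](NC(=O)[C@H](CCC(=O)O)NC(=O)c1ccc(N(C)Cc2cnc3nc(N)nc(N)c3n2)cc1)C(=O)OCC` gives 10 ug/mL, and compound 3 `CCOC(=O)CC[C@H](NC(=O)CC[C@@H](NC(=O)c1ccc(N(C)Cc2cnc3nc(N)nc(N)c3n2)cc1)C(=O)N[C@@H](CCC(=O)OCC)C(=O)OCC)C(=O)OCC` gives 9 ug/mL. Among the compounds with values here, of these three numbers, the one for compound 2 is the highest; its gap to compound 3 lies within the usual scatter of such measurements, so the two cannot be told apart, whereas its gap to compound 1 lies beyond the scatter.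

Compound 4 `CCOC(=O)CC[C@H](NC(=O)c1ccc(N(C)Cc2cnc3nc(N)nc(N)c3n2)cc1)C(=O)N[C@@H](CCC(=O)OCC)C(=O)OCC` has not been measured in this assay. It is reached from compound 2 by a single change: ethyl in place of hydrogen on an oxygen next to a carbonyl group. Within the data shown here, the effect of this particular change has not been measured anywhere in the shared core, so no directly comparable step is available.

Among the measured compounds shown here, the only guide is that compound 1, which carries ethyl on every such oxygen, gives 1.8 ug/mL, a lower number than compound 2, while compound 3, also carrying ethyl on every such oxygen, gives 9 ug/mL. On that basis a modest step toward a lower number is expected, a 2.2-fold lower number from compound 2 to compound 4 (0.35 log units; beyond the scatter), of a size near the edge of the scatter. Compound 4 is therefore estimated at 4.5 ug/mL, within a range from 1.5 ug/mL to 12 ug/mL.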

Compound 4, concentration for 50% inhibition: 0.85 ug/mL
Estimate against measurement, compound 4: 5.3-fold (0.72 log units) above; measured number outside the range, below it.
By their numbers in this assay, from the lowest: compound 4; then compound 1; then compounds 3 and 2 (each within the scatter of the next).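

In this assay, replacing carboxy with ethoxycarbonyl gives a 12-fold lower number from compound 2 to compound 4 (1.07 log units; beyond the scatter), so this one change, ethyl in place of hydrogen on an oxygen next to a carbonyl group, is enough on its own to produce a large shift towards stronger inhibition. The earlier compounds shown here could not show this, as no two of them differed in only one place, and the effect of this change could not be separated from that of the other differences in their structures. No measurement available here accounts for the size of this step.

The compounds shown leave open whether the step depends on ethyl itself, or whether methyl, a longer chain such as butyl, or benzyl on the same oxygen would give a similar result, as would an amide in place of the ethoxycarbonyl group. From the compounds shown here alone, it also remains open whether the same change from hydroxy to ethoxy at a different carboxy group would give a step of similar size, since this single pair speaks for one place only.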